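The compounds below may be only part of what the source reports. "The series", "measured", "known", "first", "only" and "open" are said of these compounds alone.

Measured so far:
Compound 1, `COc1cccc(/C=C2\CCC/C(=C\c3cccc(Br)c3)C2=O)c1OC` — in a functional assay on A549 cells (Homo sapiens) for cytotoxicity, read by MTT assay, with a stated time of 72 h (a higher number here means a weaker inhibitor, a lower number a stronger inhibitor), compound 1 gives > 20000 nM, which is a limit of the assay rather than a number.
Compound 2, `COc1ccc(/C=C2\CCC/C(=C\c3cccc(OC)c3OC)C2=O)cc1` — in this assay compound 2 gives > 20000 nM, again a limit of the assay.

Compound 1 therefore has no measured number of its own; it sits at the limit of > 20000 nM in this assay, at which 2 of the 2 values shown sit, and so does every other value here. The piece follows the change from compound 1 to compound 3, `COc1cccc(/C=C2\CCC/C(=C\c3ccc(O)c(Cl)c3)C2=O)c1OC`: 3-chloro-4-hydroxyphenyl in place of 3-bromophenyl on a double-bonded chain carbon bound to a double-bonded ring carbon. For the measured compounds named here, the only measured step that touches this part of the molecule is a step that the two limits leave unreadable from compound 1 to compound 2, and since both of its ends are limits, it cannot be read and gives no size in either direction. There is thus no basis in the numbers for expecting compound 3 to move out of the range in which compound 1 stands. Compound 3 is expected at 25000 nM, within 8000 nM to 60000 nM. The step that the limit leaves unreadable from compound 1 to compound 3 is estimated, not measured.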

Compound 3, half-maximal inhibitory concentration: > 20000 nM
Compound 3 gave a limit, no number (the forecaster's own chance of this, stated with the estimate: 70%); the middle value does not contradict the limit.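

For the compounds shown here, compound 3 also gives a limit of the assay, so no step among compound 1, compound 2 and compound 3 can be read: the limit of > 20000 nM in this assay, at which 3 of the 3 values shown sit. The compounds shown leave open whether any group at this place gives in this assay a number rather than a limit.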